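This account rests on a few compounds, and the source may have more. Where it says the series, first, only, none or still open, it means among the compounds named here.

Working notes on a functional assay on HOS-TE85 cells (Homo sapiens) for inhibition, read by CCK-8 assay, with a stated time of 72 h; on this read-out lower numbers stand for stronger inhibition and higher numbers for weaker inhibition. Going by the values given here, compound 3 (`COc1ccc(F)cc1N1C(=O)CSC1c1cccc(C(=O)NCCCCc2ccccc2)c1`) gives 8.8 nM, the lowest number so far. Compound 1 (`COc1ccc(F)cc1N1C(=O)CSC1c1cccc(C(=O)NCCCCn2cccn2)c1`) gives 97.3 nM. Compound 2 (`CC(C)(C)c1conc1N1C(=O)CSC1c1cccc(C(=O)NCCCCc2ccccc2)c1`) reaches only a limit of the assay, > 1000 nM.

Compound 4 (`COc1cc(F)ccc1N1C(=O)CSC1c1cccc(C(=O)NCCCCc2ccccc2)c1`) is related to compound 3 by 4-fluoro-2-methoxyphenyl in place of 5-fluoro-2-methoxyphenyl on an amide-type nitrogen in a ring. The most relevant measured change is an at least 110-fold lower number from compound 2 to compound 3 (2.05 log units; beyond the scatter), a large step at this same place, but it exchanges a whole group. The large 11-fold lower number from compound 1 to compound 3 (1.04 log units; beyond the scatter) concerns the chain instead and bears less directly. A moderate rise is therefore expected, smaller than either measured step, and the expected change is a 2.8-fold higher number from compound 3 to compound 4 (0.45 log units; beyond the scatter). For compound 4 the estimated value is 25 nM, with an expected range of 6 nM to 120 nM.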

Compound 4, half-maximal inhibitory concentration: 71.1 nM
Beside the measured number, compound 4's estimate is 2.8-fold (0.45 log units) below it, within the range that was stated.
By their numbers in this assay, from the lowest: compound 3; then compounds 4 and 1 (each within the scatter of the next). At a limit, above all of these: compound 2.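

Moving the fluorine alone, with the atom count unchanged, is enough to shift the read-out: 4-fluoro-2-methoxyphenyl in place of 5-fluoro-2-methoxyphenyl gives an 8.1-fold higher number from compound 3 to compound 4 (0.91 log units; beyond the scatter). This position therefore responds to the fluorine's place on the ring, not only to a whole-group exchange. The step of an at least 14-fold lower number from compound 2 to compound 4 (1.14 log units; beyond the scatter) shows that the new aryl group still stays clear of compound 2, whose entry is a limit and not a number: the limit of > 1000 nM in this assay, at which 1 of the 4 values shown sits.

Still open, from the compounds shown here alone, is how a chlorine atom or a methyl group in place of the fluorine would read here. Also open, going by these compounds, is whether the 1H-pyrazol-1-yl chain of compound 1 would tolerate 4-fluoro-2-methoxyphenyl.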